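This account rests on a few compounds, and the source may have more. Where it says the series, first, only, none or still open, it means among the compounds named here.

Values so far in a functional assay on HUVEC cells (Homo sapiens), read by BrdU incorporation, with a stated time of 72 h; a lower number here means a stronger inhibitor, a higher number a weaker inhibitor
compound 1 `Cc1cccc2cc(/C=C/C(=O)c3ccc(I)s3)c(Cl)nc12` gives 284 nM
compound 2 `Cc1cccc2cc(/C=C/C(=O)c3ccc(Br)s3)c(Cl)nc12` gives 243 nM

Compound 2 (243 nM) sits within the scatter of compound 1. Compound 3 `Cc1cccc2cc(/C=C/C(=O)c3ccc(Cl)s3)c(Cl)nc12` carries chloro in place of bromo on an aromatic carbon. Among the compounds with values here, only one measured step bears on this, the exchange of iodo for bromo (a 1.2-fold lower number from compound 1 to compound 2 (0.07 log units; within the scatter)), so no step beyond the scatter is expected in this assay. The expected step (a 1.1-fold higher number from compound 2 to compound 3 (0.03 log units; within the scatter)) is correspondingly small. For compound 3 the estimate is 260 nM (expected range 130 nM to 520 nM).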

Compound 3, half-maximal inhibitory concentration: 116 nM
Compound 3: middle estimate off by 2.2-fold (0.35 log units), on the high side, and the stated range ends above it.
By their numbers in this assay, from the lowest: compound 3; then compounds 2 and 1 (each within the scatter of the next).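

In this assay the halogen at this place, next to the ring sulfur, turns out to matter: chloro in place of bromo gives a 2.1-fold lower number from compound 2 to compound 3 (0.32 log units; beyond the scatter) and chloro in place of iodo gives a 2.4-fold lower number from compound 1 to compound 3 (0.39 log units; beyond the scatter) even though bromo and iodo had stayed within the scatter of each other. Both steps are modest, and the position has so far answered only to this one exchange of halogen. No measured evidence accounts for the difference.

On these data alone, it remains open whether fluoro, a methyl group, a nitrile or an amine at this place would continue the move to lower numbers. Also open, as far as these compounds go, is whether the 5-chlorothiophen-2-yl group keeps its edge when the shared core is changed.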